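A few compounds are considered here, and "the series" means these few. Any claim that something is new, unique, unknown or untested is made for them only; others in the source may bear on it.

Compound 1 `Cc1ccc(C(=O)Nc2cccc(-c3oc4cc(-c5ccc(F)cc5)ccc4c(=O)c3O)c2)cc1` carries a 4-methylphenyl on a carbonyl carbon. In a functional assay on HepG2 cells (Homo sapiens) for antiproliferative activity, read by CCK-8 assay, with a stated time of 72 h (a higher number here means a weaker inhibitor, a lower number a stronger inhibitor), compound 1 gives 2320 nM, the lowest of the three measured numbers. Compound 2 `O=C(Nc1cccc(-c2oc3cc(-c4ccc(F)cc4)ccc3c(=O)c2O)c1)c1cccc(F)c1` gives 15500 nM in this assay, and compound 3 `CCc1ccc(C(=O)Nc2cccc(-c3oc4cc(-c5ccc(F)cc5)ccc4c(=O)c3O)c2)cc1` gives 20600 nM. Both departures from compound 1 raise the number: a 6.7-fold higher number from compound 1 to compound 2 (0.82 log units; beyond the scatter) and an 8.9-fold higher number from compound 1 to compound 3 (0.95 log units; beyond the scatter). Compound 4 `COc1ccc(C(=O)Nc2cccc(-c3oc4cc(-c5ccc(F)cc5)ccc4c(=O)c3O)c2)c(F)c1` differs from compound 1 by 2-fluoro-4-methoxyphenyl in place of 4-methylphenyl on a carbonyl carbon. The two measured steps that bear on this change both replaced the 4-methylphenyl and both weakened inhibition beyond the scatter, so a further replacement is expected to weaken it too, though neither step carries the same entering group. The step is estimated as a 3.4-fold higher number from compound 1 to compound 4 (0.54 log units; beyond the scatter). Compound 4 is therefore expected to give about 8000 nM, within a range from 2500 nM to 30000 nM.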

Compound 4, half-maximal inhibitory concentration: 45300 nM
Beside the measured number, compound 4's estimate is 5.7-fold (0.75 log units) below it; measured number outside the range, above it.
By their numbers in this assay, from the lowest: compound 1; then compounds 2 and 3 (each within the scatter of the next); then compound 4.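

In this assay the 2-fluoro-4-methoxyphenyl on the carbonyl carbon gives a 20-fold higher number from compound 1 to compound 4 (1.29 log units; beyond the scatter) and so moves further from the 4-methylphenyl than either earlier replacement. It also stands clear of those two, with a 2.2-fold higher number from compound 3 to compound 4 (0.34 log units; beyond the scatter) and a 2.9-fold higher number from compound 2 to compound 4 (0.47 log units; beyond the scatter) as the printed steps. All three replacements shown therefore raise the number, and compound 4, the only one whose entering group has a hydrogen-bond acceptor, is the weakest inhibitor of the four.

On these data alone, the fluorine and the methoxy entered together, so their separate shares remain open, as does the effect of an amine or a carboxylic acid on this ring. No supporting evidence accounts for the order of these compounds.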